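The source may hold more compounds than are shown below. What is called first, only, known or untested is meant among the compounds shown, and "the series" means these compounds.

Compound 1 `COc1ccc(CS(=O)(=O)/C=C/c2c(OC)cccc2OC)cc1N`: in a functional assay on DU-145 cells (Homo sapiens) for cytotoxicity, read by trypan blue exclusion, with a stated time of 96 h (on this read-out lower numbers stand for stronger inhibition and higher numbers for weaker inhibition), compound 1 gives 50 nM.
Compound 2 `COc1ccc(CS(=O)(=O)/C=C/c2c(OC)cc(OC)cc2OC)c(N)c1`: compound 2 gives 25 nM.
Compound 3 `COc1cc(OC)c(/C=C/S(=O)(=O)Cc2ccc(OC)c(N)c2)c(OC)c1`: compound 3 gives 4 nM.

Compound 3 gives the lowest number of the three, and since both a 13-fold lower number from compound 1 to compound 3 (1.10 log units; beyond the scatter) and a 6.3-fold lower number from compound 2 to compound 3 (0.80 log units; beyond the scatter) lie beyond the scatter, it is the strongest compound measured. Compound 4 `COc1cc(OC)c(/C=C/S(=O)(=O)Cc2ccc(OC)c(NC(F)(F)C(=O)O)c2)c(OC)c1` differs from compound 3 in one place: carboxy(difluoro)methyl in place of hydrogen on a nitrogen on an aromatic ring. Neither measured step touches this nitrogen: one puts methoxy in place of hydrogen on an aromatic carbon, the other puts 3-amino-4-methoxyphenyl in place of 2-amino-4-methoxyphenyl. The measured compounds therefore give no direct guide, and the expected step of a 7.5-fold higher number from compound 3 to compound 4 (0.88 log units; beyond the scatter) carries a wide range. Compound 4 is estimated to give 30 nM, expected between 4 nM and 300 nM.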

Compound 4, half-maximal inhibitory concentration: 150 nM
Estimate against measurement, compound 4: 5.0-fold (0.70 log units) below, and the stated range covers the measured number.
By their numbers in this assay, from the lowest: compound 3; then compounds 2 and 1 (each within the scatter of the next); then compound 4.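

In this assay the amino nitrogen proves sensitive to change: carboxy(difluoro)methyl in place of hydrogen gives a 38-fold higher number from compound 3 to compound 4 (1.57 log units; beyond the scatter) and this large step is the first change shown at this nitrogen. The hydrogen of compound 3 therefore cannot be swapped for this group without a clear loss of strength, although a single group cannot speak for every replacement here.

From the compounds shown here alone, whether a methyl or an acetyl group on the same nitrogen would fare better stays open, as does the role of the two fluorine atoms. No measurement at hand explains the rise in the number.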